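The source may hold more compounds than are shown below. What is called first, only, known or untested is meant among the compounds shown, and "the series" means these compounds.

Working notes on the series. For the measured compounds named here, compound 1 `CC(C(=O)NCc1ccc(C(C)(C)C)nc1N1CCCCCC1)c1ccc(NS(C)(=O)=O)c(F)c1` is the reference point; in an assay on cells for antagonist activity at transient receptor potential cation channel subfamily V member 1 (Homo sapiens), read by FLIPR and calcium flux, with a stated time of 6 min (on this read-out lower numbers stand for stronger inhibition and higher numbers for weaker inhibition), compound 1 gives 0.9 nM, which is the lowest of the two numbers recorded so far, though only one other compound has been measured. Going by the values given here, the nearest neighbour is compound 2 `CCCCCCSc1nc(C(C)(C)C)ccc1CNC(=O)C(C)c1ccc(NS(C)(=O)=O)c(F)c1`, which in this assay gives 1.5 nM; the single step recorded, a 1.7-fold higher number from compound 1 to compound 2 (0.22 log units; within the scatter), lies within the scatter, so the two values cannot be ordered.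

Compound 3 `CC(C(=O)NCc1ccc(C(C)(C)C)nc1SCCCN(C)C)c1ccc(NS(C)(=O)=O)c(F)c1` has not been measured. Relative to compound 1 the change is (3-(dimethylamino)propyl)sulfanyl in place of azepan-1-yl on an aromatic carbon, at the same place on the shared core where compound 2 differs from compound 1: a sulfanyl chain again replaces azepan-1-yl on an aromatic carbon, here carrying a dimethylamino group at the end of the chain. Among the compounds with values here, the only step that bears on this, a 1.7-fold higher number from compound 1 to compound 2 (0.22 log units; within the scatter), was within the scatter, so no step beyond the scatter is expected in this assay for compound 3 either. Compound 3 is therefore expected to give about 1.5 nM in this assay, with a range of 0.5 nM to 5 nM, which corresponds to an expected step of a 1.7-fold higher number from compound 1 to compound 3 (0.22 log units; within the scatter).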

Compound 3, inhibition constant: 51.8 nM
Beside the measured number, compound 3's estimate is 35-fold (1.54 log units) below it; measured number above the stated range.
By their numbers in this assay, from the lowest: compounds 1 and 2 (each within the scatter of the next); then compound 3.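

With (3-(dimethylamino)propyl)sulfanyl in place of azepan-1-yl, this assay shows a 58-fold higher number from compound 1 to compound 3 (1.76 log units; beyond the scatter) and so establishes that this position is not indifferent to the group placed on it, which the earlier step within the scatter could not show. The sulfanyl link alone does not go with this loss, as hexylsulfanyl stays within the scatter of azepan-1-yl, while the change at the end of the chain, dimethylamino in place of propyl, gives a 35-fold higher number from compound 2 to compound 3 (1.54 log units; beyond the scatter) and thus tracks the large step in this pair. No measurement in hand bears on why the dimethylamino group is accompanied by a step of this size.

On these data alone, it remains open whether the step belongs to the dimethylamino group specifically or to any amine at the end of a chain, a question that a morpholine, a piperidine or a primary amine in the same place would address. A hydroxyl or methoxy group at the end of the chain, and a shorter or longer chain carrying the same dimethylamino group, would further show how much of the step depends on the nitrogen and how much on its distance from the sulfur.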